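Removing the isopropyl group: cytotoxicity limit expected to hold

A few compounds are considered here, and "the series" means these few. Any claim that something is new, unique, unknown or untested is made for them only; others in the source may bear on it.

Compound 1 `CCOC(=O)c1c(-c2cccc(-c3ccccc3)c2)[nH]c2cc(OC)ccc2c1=O` in an ADME assay on HepG2 cells (Homo sapiens) for cytotoxicity, read by luminescence, with a stated time of 72 h (on this read-out higher numbers stand for an effect only at larger amounts of compound and lower numbers for an effect already at smaller amounts), gives only a limit, > 21500 nM.
Compound 2 `CCOC(=O)c1c(-c2cccc(-c3ccccc3)c2)[nH]c2cc(OC(C)C)ccc2c1=O` gives only a limit in this assay, > 21500 nM.
Compound 3 `CCOC(=O)c1c(-c2cccc(OC)c2)[nH]c2cc(OC(C)C)ccc2c1=O` also gives only a limit in this assay, > 21500 nM.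

Compound 2 therefore stands at the limit of this assay, and the two other measured compounds stand there too; none of the three returns a number, so nothing separates them on what has been measured. The unmeasured compound 4 `CCOC(=O)c1c(-c2cccc(-c3ccccc3)c2)[nH]c2cc(O)ccc2c1=O` differs from compound 2 by hydrogen in place of isopropyl on an oxygen on an aromatic ring. Going by the values given here, two measured steps touch the same part of the molecule. The step that the two limits leave unreadable from compound 1 to compound 2 and the step that the two limits leave unreadable from compound 2 to compound 3 both end at the limit, and their size cannot be read because of the limit of > 21500 nM in this assay, at which 3 of the 3 values shown sit. Among the compounds with values here, there is thus no measured step whose size could be carried over to the change from compound 2 to compound 4, and the only observation is that every change tried so far has left the value at the limit. Compound 4 is expected to remain there as well, the step that the limit leaves unreadable from compound 2 to compound 4 being expected to stay within the scatter. Compound 4 is estimated at 30000 nM, with a range from 15000 nM to 60000 nM.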

Compound 4, half-maximal effective concentration: > 21500 nM
Compound 4 was reported as a limit; the forecaster's own chance of this, stated with the estimate: 80%; the middle value does not contradict the limit.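

Compound 4 returns only a limit, as compound 1 and compound 2 do, so the steps from compound 2 to compound 4 and from compound 1 to compound 4 cannot be read, because all of these values sit at one limit: the limit of > 21500 nM in this assay, at which 4 of the 4 values shown sit.

The compounds shown leave open whether isopropoxy, methoxy and hydroxy differ at all in this assay, and at what amount any of these compounds would show an effect there.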